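Can a benzyl group replace the fluorinated chain?

This account rests on a few compounds, and the source may have more. Where it says the series, first, only, none or still open, it means among the compounds named here.

Compound 1 `C[C@H](Oc1ccc(S(C)(=O)=O)cc1C(=O)N1Cc2cc(C(F)(F)F)cnc2C1)C(F)(F)F`: 280 ug/mL
Compound 2 `CS(=O)(=O)c1ccc(OCCC(F)(F)F)c(C(=O)N2Cc3cc(C(F)(F)F)cnc3C2)c1`: 513 ug/mL

Both values come from a physicochemical assay for solubility; on this read-out lower numbers stand for lower solubility and higher numbers for higher solubility. Going by the values given here, the position of compound 2 is set by the only measured step, a 1.8-fold higher number from compound 1 to compound 2 (0.26 log units; within the scatter). The two values cannot be told apart, so compound 2 stands level with compound 1 in this small set.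

Compound 3 `CS(=O)(=O)c1ccc(OCc2ccccc2)c(C(=O)N2Cc3cc(C(F)(F)F)cnc3C2)c1` keeps the shared core and alters one group: phenyl in place of 2,2,2-trifluoroethyl on a saturated chain carbon bound to an oxygen on an aromatic ring. Cut one bond further out, the same difference reads 3,3,3-trifluoropropyl to benzyl.

The measured step gives only a weak guide. Among the compounds with values here, it exchanged one fluorine-bearing group for another, and no measured compound carries a phenyl ring in this place. The size of the new step therefore cannot be read from the data, and the direction is a judgement rather than a measured trend. A move to a lower number in this assay is expected, with a wide margin. The expected step is a 2.6-fold lower number from compound 2 to compound 3 (0.41 log units; beyond the scatter). The estimated value for compound 3 is 200 ug/mL, with an expected range from 60 ug/mL to 500 ug/mL.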

Compound 3, solubility: 72 ug/mL
For compound 3 the middle estimate is 2.8-fold (0.44 log units) above the measured one; the range from low to high includes it.
By their numbers in this assay, from the lowest: compound 3; then compounds 1 and 2 (each within the scatter of the next).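

In this assay, going by these compounds alone, the benzyl group of compound 3 brings the first change at this position that lies beyond the scatter: a 7.1-fold lower number from compound 2 to compound 3 (0.85 log units; beyond the scatter), and a 3.9-fold lower number from compound 1 to compound 3 (0.59 log units; beyond the scatter). This place on the molecule therefore does matter for this read-out, since the two fluorinated chains of compound 1 and compound 2 stand level with each other, while compound 3, with its phenyl ring and no fluorine in this group, stands clearly lower than both. No evidence is available here to explain the drop.

Compound 3 loses the fluorine atoms and gains an aromatic ring in a single exchange, so the compounds shown leave open which of the two goes with the lower number. Going by these compounds, it also remains open whether a cyclohexylmethyl group, a pyridylmethyl group with a nitrogen in its ring, or a plain propyl chain, each on an oxygen on an aromatic ring, would stand with compound 3 or with compound 1 and compound 2.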